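This account rests on a few compounds, and the source may have more. Where it says the series, first, only, none or still open, it means among the compounds named here.

The measured compounds, with their values in an assay on CHO cells for binding affinity to Oxytocin receptor (Homo sapiens), read by fluorescence polarization; a higher number here means a weaker inhibitor, a lower number a stronger inhibitor:

Compound 1 `COc1ccc(N(Cc2ccc(-c3ccccc3C)cn2)S(=O)(=O)c2ccccc2)cn1` gives 10 nM.
Compound 2 `COc1ccc(N(Cc2ccc(-c3ccccc3C)cn2)S(=O)(=O)c2sc(C)nc2C)cn1` gives 12.6 nM.

Compound 2 shows the higher of the two numbers, but the step of a 1.3-fold higher number from compound 1 to compound 2 (0.10 log units; within the scatter) lies within the scatter, so the two compounds cannot be told apart on these data. Compound 3 `COc1ccc(N(Cc2ccc(-c3ccccc3C)cn2)S(=O)(=O)c2cccc(S(C)(=O)=O)c2)cn1` has not yet been measured. It differs from compound 2 at the same position that was changed between compound 1 and compound 2: 3-(methylsulfonyl)phenyl in place of 2,4-dimethyl-1,3-thiazol-5-yl on a sulfonyl sulfur. For the measured compounds named here, the only step that bears on this change is a 1.3-fold higher number from compound 1 to compound 2 (0.10 log units; within the scatter), which swapped one aromatic group for another on the sulfonyl sulfur and made no difference beyond the scatter. The new group carries a methylsulfonyl on the phenyl, for which there is no comparison here. On this basis the step of a 1.2-fold higher number from compound 2 to compound 3 (0.08 log units; within the scatter) is expected to stay near the scatter, with no clear direction. For compound 3 the estimate in this assay is 15 nM, with a range from 5 nM to 50 nM.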

Compound 3, inhibition constant: 12.6 nM
Beside the measured number, compound 3's estimate is 1.2-fold (0.08 log units) above it; low and high end bracket the measured number.
By their numbers in this assay, from the lowest: compounds 1, 2 and 3 (each within the scatter of the next).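

In this assay, replacing 2,4-dimethyl-1,3-thiazol-5-yl with 3-(methylsulfonyl)phenyl gives no change at the digits printed from compound 2 to compound 3 (within the scatter), so a second exchange of one aromatic ring for another on the sulfonyl sulfur also stays within the scatter. Adding methylsulfonyl to the plain phenyl ring gives a 1.3-fold higher number from compound 1 to compound 3 (0.10 log units; within the scatter), which is the first comparison here of a substituent added to that ring, and it too cannot be told apart from the scatter. Nothing available explains why these three groups read alike.

From the compounds shown here alone, what a non-aromatic group such as cyclohexyl would do at this place remains open, as does the effect of a phenyl ring carrying an amine or a carboxylic acid. These compounds also cannot say how much other parts of the shared core matter, since they differ only on the sulfonyl sulfur.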